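Swapping the side chain of compound 1 for a carbamoyl

This account rests on a few compounds, and the source may have more. Where it says the series, first, only, none or still open, it means among the compounds named here.

Among the measured compounds shown here, in a functional assay on the whole organism (Tail, strain ICR) with Mus musculus as the target, in the tail flick test, with a stated time of 30 min, at a dose of 25 umol/kg by the oral route (on this read-out higher numbers stand for a stronger effect at the one dose given and lower numbers for a weaker effect), compound 1 `N=C(N)NCCC[C@H](NC(=O)CN(c1nc(Cl)nc2[nH]cnc12)C1CC1)C(=O)O` gives 45.4%, the highest of the three numbers so far. Compound 2 `N=C(N)NCCC[C@H](NC(=O)CN(c1nc(Cl)nc2[nH]cnc12)C1CC1)C(=O)OCc1ccccc1` gives 23.2% in this assay, and compound 3 `N=C(N)NCCC[C@H](NC(=O)CN(c1ncnc2c1ncn2C1CCCCO1)C1CC1)C(=O)OCc1ccccc1` gives 34.3%. For the measured compounds named here, the only single-point step known, a number 22.2 percentage points lower from compound 1 to compound 2 (beyond the scatter), concerns the ester end of the molecule. Compound 4 `NC(=O)CC[C@H](NC(=O)CN(c1nc(Cl)nc2[nH]cnc12)C1CC1)C(=O)O` differs from compound 1 elsewhere: a group of 3 heavy atoms (1 carbon, 1 nitrogen, 1 oxygen; no ring) in place of a group of 5 heavy atoms (2 carbon, 3 nitrogen; no ring), on a saturated chain carbon, three bonds along the chain from an amide-type nitrogen and a carbonyl carbon. Going by the values given here, no measured step touches this part of the structure, so the direction of the change cannot be read from the three compounds; a drop of some size seems more likely than a rise, with wide uncertainty. For compound 4 in this assay the expected value is 32% (range 8% to 58%), an expected step of a number 13.4 percentage points lower from compound 1 to compound 4 (beyond the scatter).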

Compound 4, a percentage reported as activity, at one dose (the size of the read-out at that dose, not a potency): 33.1%
Compound 4: the middle estimate sits 1.1 percentage points below what was measured; measured number inside the range.
By their numbers in this assay, from the lowest: compounds 2, 4 and 3 (each within the scatter of the next, the first and the last beyond it); then compound 1.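

In this assay, among the compounds shown here, the carbamoyl in place of the group of 5 heavy atoms gives a number 12.3 percentage points lower from compound 1 to compound 4 (beyond the scatter) and this is the first step read at the side chain rather than the ester end. The read-out therefore responds to this position, yet compound 4 still retains a clear effect with this smaller group. Nothing available explains the step.

From the compounds shown here alone, whether an amine, a carboxylic acid or a longer chain ending in carbamoyl would bring the number closer to that of compound 1 stays open. So does whether a benzyl ester of compound 4 would lower its number as it did for compound 1.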